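Trifluoromethylphenyl placement and an added chlorine

The compounds below may be only part of what the source reports. "The series", "measured", "known", "first", "only" and "open" are said of these compounds alone.

Values so far in a functional assay on RS4-11 cells (Homo sapiens) for inhibition, read by CCK-8 assay, with a stated time of 72 h (on this read-out higher numbers stand for weaker inhibition and lower numbers for stronger inhibition), are these
compound 1 `CC1(C)CCC(CN2CCN(c3ccc(C(=O)NS(=O)(=O)c4ccc(NCC5CCOCC5)c([N+](=O)[O-])c4)c(Oc4cnc5[nH]ccc5c4)c3)CC2)=C(c2ccc(C(F)(F)F)cc2)C1` gives 6.2 nM
compound 2 `CC1(C)CCC(CN2CCN(c3ccc(C(=O)NS(=O)(=O)c4ccc(NCC5CCOCC5)c([N+](=O)[O-])c4)c(Oc4cnc5[nH]ccc5c4)c3)CC2)=C(c2cccc(C(F)(F)F)c2)C1` gives 63 nM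
compound 3 `CC1(C)CCC(CN2CCN(c3ccc(C(=O)NS(=O)(=O)c4ccc(NCC5CCOCC5)c([N+](=O)[O-])c4)c(Oc4cnc5[nH]ccc5c4)c3)CC2)=C(c2ccc(C(F)(F)F)c(Cl)c2)C1` is not yet measured

Among the measured compounds shown here, compound 2 stands highest of the two measured numbers, and compound 1 is its only neighbour. The change to compound 3 is 3-chloro-4-(trifluoromethyl)phenyl in place of 3-(trifluoromethyl)phenyl on a double-bonded ring carbon on the same double-bonded ring carbon. For the measured compounds named here, the one measured step bearing on it is a 10-fold higher number from compound 1 to compound 2 (1.01 log units; beyond the scatter) and is large, beyond the scatter. Going by the values given here, compound 3 regains the 4-(trifluoromethyl) pattern of compound 1 (6.2 nM) but also carries a chlorine, and no measured compound shows what the chlorine does alone. A large drop in this assay is therefore expected, most of the way back towards compound 1. The expected size is a 6.3-fold lower number from compound 2 to compound 3 (0.80 log units; beyond the scatter) in this estimate. The estimated value for compound 3 is 10 nM within an expected range from 3.5 nM to 30 nM for now.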

Compound 3, half-maximal inhibitory concentration: 81 nM
Compound 3: middle estimate off by 8.1-fold (0.91 log units), on the low side, outside the stated range (above it).
By their numbers in this assay, from the lowest: compound 1; then compounds 2 and 3 (each within the scatter of the next).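

In this assay, chloro in place of hydrogen on the aromatic ring of compound 1 gives a 13-fold higher number from compound 1 to compound 3 (1.12 log units; beyond the scatter) and is a large loss, so the 4-(trifluoromethyl) pattern alone does not secure the low number of compound 1. Going the other way, 3-chloro-4-(trifluoromethyl)phenyl in place of 3-(trifluoromethyl)phenyl gives a 1.3-fold higher number from compound 2 to compound 3 (0.11 log units; within the scatter) and stays within the scatter, so the two substituted patterns of compound 2 and compound 3 sit together, with compound 1 apart from both. No available measurement accounts for this result.

The compounds shown leave open whether the loss belongs to chlorine itself or would also follow a fluorine, a methyl or a nitrile on the same aromatic carbon. They also leave open how a phenyl ring with chloro alone would read.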